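Ester Change Carried from One Core to Another

The source may hold more compounds than are shown below. What is called first, only, known or untested is meant among the compounds shown, and "the series" means these compounds.

Four compounds share a core and differ at two places. Compound 1 `CC1=C(C(=O)OC2CCCC2)C(c2ccoc2)NC(=O)N1` carries a cyclopentyl ester and a furan-3-yl group; in an assay on membranes from HEK293 cells for displacement of a labelled ligand from adenosine receptor A2b (Homo sapiens), read by scintillation counting, with a stated time of 30 min (a lower number here means a stronger inhibitor, a higher number a weaker inhibitor), compound 1 gives 1010 nM. Compound 2 `CC1=C(C(=O)OCC2CC2)C(c2ccoc2)NC(=O)N1` differs by cyclopropylmethyl in place of cyclopentyl on an oxygen next to a carbonyl group, and compound 2 gives 426 nM, a step of a 2.4-fold lower number from compound 1 to compound 2 (0.37 log units; beyond the scatter). Compound 3 `CC1=C(C(=O)OC2CCCC2)C(c2ccsc2)NC(=O)N1` differs from compound 1 by thiophen-3-yl in place of furan-3-yl on a saturated ring carbon, and compound 3 gives 659 nM, a step of a 1.5-fold lower number from compound 1 to compound 3 (0.19 log units; within the scatter).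

Compound 4 `CC1=C(C(=O)OCC2CC2)C(c2ccsc2)NC(=O)N1` has not been measured. It differs from compound 3 by cyclopropylmethyl in place of cyclopentyl on an oxygen next to a carbonyl group, which is the same change that was made from compound 1 to compound 2, at the same place. The two cores differ by the thiophen-3-yl in place of furan-3-yl described above. Because that first change gave a 2.4-fold lower number from compound 1 to compound 2 (0.37 log units; beyond the scatter), the same change is expected to give a step of a 2.4-fold lower number from compound 3 to compound 4 (0.37 log units; beyond the scatter) in this assay from compound 3. Compound 4 is therefore estimated at 280 nM, with a likely range from 140 nM to 560 nM.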

Compound 4, inhibition constant: 724 nM
Estimate against measurement, compound 4: 2.6-fold (0.41 log units) below, and the stated range ends below it.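

In this assay, with the thiophen-3-yl group in place, the change from cyclopentyl to cyclopropylmethyl gives a 1.1-fold higher number from compound 3 to compound 4 (0.04 log units; within the scatter), so the step beyond the scatter seen with the furan-3-yl group does not appear again, yet the two steps cannot be told apart: the same change on two cores in this assay, a 2.4-fold lower number (0.37 log units; beyond the scatter) from compound 1 to compound 2 and a 1.1-fold higher number (0.04 log units; within the scatter) from compound 3 to compound 4, 2.6-fold (0.42 log units) apart, within the scatter of two such steps. Read the other way, with the cyclopropylmethyl ester in place, thiophen-3-yl in place of furan-3-yl gives a 1.7-fold higher number from compound 2 to compound 4 (0.23 log units; within the scatter), and this step also cannot be told apart from its earlier counterpart: the same change on two cores in this assay, a 1.5-fold lower number (0.19 log units; within the scatter) from compound 1 to compound 3 and a 1.7-fold higher number (0.23 log units; within the scatter) from compound 2 to compound 4, 2.6-fold (0.42 log units) apart, within the scatter of two such steps. The four compounds therefore show neither that the ester change carries from one core to the other nor that it fails to, and a single pair of cores cannot settle whether its size depends on the other group.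

The compounds shown leave open how the same ester change behaves with a phenyl group in place of furan-3-yl or thiophen-3-yl. They also leave open what a longer chain, such as n-butyl, would give on the ester oxygen.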